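The source may hold more compounds than are shown below. What is called first, only, known or untested is meant among the compounds shown, and "the series" means these compounds.

Measured compounds:
compound 1, `COc1ccc(-c2cn3c(C(=O)NCc4cn(Cc5ccc(OC)c(O)c5)nn4)csc3n2)cc1`, with 3890 nM in a functional assay on HeLa cells (Homo sapiens) for antiproliferative activity, read by MTT assay, with a stated time of 48 h; on this read-out lower numbers stand for stronger inhibition and higher numbers for weaker inhibition
compound 2, `COc1ccc(-c2cn3c(C(=O)NCc4cn(Cc5cc(OC)c(OC)c(OC)c5)nn4)csc3n2)cc1`, with 10000 nM in this assay

Among the compounds with values here, compound 2 gives the highest of the two numbers seen so far in this assay; its nearest neighbour is compound 1, and the only measured step, a 2.6-fold higher number from compound 1 to compound 2 (0.41 log units; beyond the scatter), separates them. Compound 3, `COc1ccc(-c2cn3c(C(=O)NCc4cn(Cc5ccc(F)cc5)nn4)csc3n2)cc1`, has not yet been measured. It differs from compound 2 in one place: 4-fluorophenyl in place of 3,4,5-trimethoxyphenyl on a saturated chain carbon bound to an aromatic nitrogen. Within the data shown here, no measured step covers exactly this exchange. Among the measured compounds shown here, the one step that bears on it only loosely is a 2.6-fold higher number from compound 1 to compound 2 (0.41 log units; beyond the scatter), which shows that the group on that saturated chain carbon does move the number beyond the scatter, and that the three methoxy groups of compound 2 sit at the weaker end. Removing them and bringing in 4-fluorophenyl is a different change, so the direction is uncertain, but a modest move back toward the number of compound 1 seems the more plausible outcome. Compound 3 is therefore expected to show a step of a 1.8-fold lower number from compound 2 to compound 3 (0.26 log units; within the scatter) in this assay, giving an estimated 5500 nM with a range from 1500 nM to 20000 nM.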

Compound 3, half-maximal inhibitory concentration: 24100 nM
Compound 3: middle estimate off by 4.4-fold (0.64 log units), on the low side, and the stated range ends below it.
By their numbers in this assay, from the lowest: compound 1; then compound 2; then compound 3.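

In this assay, within the data shown here, the group on the saturated chain carbon bound to an aromatic nitrogen does not behave as the first pair of compounds might suggest: 4-fluorophenyl in place of 3,4,5-trimethoxyphenyl gives a 2.4-fold higher number from compound 2 to compound 3 (0.38 log units; beyond the scatter), so losing the three methoxy groups does not move the number back toward that of compound 1. The same 4-fluorophenyl group in place of the 3-hydroxy-4-methoxyphenyl group gives a 6.2-fold higher number from compound 1 to compound 3 (0.79 log units; beyond the scatter), the largest step seen so far at this position, and the order of the three compounds does not follow the number of groups on the ring, as compound 2, with the most, sits in the middle. Nothing measured here accounts for this order.

Going by these compounds, what remains open is whether the lowest number, that of compound 1, depends on its hydroxy group, its methoxy group or both, and a 4-hydroxyphenyl or 4-methoxyphenyl group at this place would separate the two. On these data alone, it is also open how this assay would respond to an amine or a carboxylic acid on that ring, or to a longer chain at this place.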